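Trimming a methoxy from a diaminoquinoxaline growth inhibitor

The compounds below may be only part of what the source reports. "The series", "measured", "known", "first", "only" and "open" are said of these compounds alone.

Of the compounds shown here, three built on a shared core have been measured in a functional assay on SK-MEL-2 cells (Homo sapiens) for inhibition, read by sulforhodamine B assay, with a stated time of 48 h; a higher number here means a weaker inhibitor of growth, a lower number a stronger inhibitor of growth. Compound 1 `COc1ccc(CNc2nc3cc(N)cc(N)c3nc2-c2ccccc2)cc1OC` gives 8710 nM, the lowest of the three numbers. Compound 2 `COc1cc(CNc2nc3cc(N)cc(N)c3nc2-c2ccccc2)cc(OC)c1OC` gives 16200 nM, and the change a 1.9-fold higher number from compound 1 to compound 2 (0.27 log units; within the scatter) stays within the scatter. Compound 3 `CCOC(=O)[C@H](CCC(=O)O)NC(=O)c1ccc(Oc2nc3cc(N)cc(N)c3nc2-c2ccccc2)cc1` gives 40700 nM, which sits well beyond the scatter above compound 1.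

The next compound, compound 4 `COc1ccc(CNc2nc3cc(N)cc(N)c3nc2-c2ccccc2)cc1`, differs from compound 1 by hydrogen in place of methoxy on an aromatic carbon; the hydrogen enters on an aromatic carbon of a six-membered aromatic ring of carbon only, ortho to a methoxy group and meta to a large group. Among the compounds with values here, the only measured step that bears on this is the one from compound 1 to compound 2, where adding a methoxy moved the number only within the scatter. Removing a methoxy is therefore expected to change this assay little, with at most a slight drift toward a lower number. Compound 4 is accordingly estimated at 7000 nM, within 2500 nM to 20000 nM, which means an expected step of a 1.2-fold lower number from compound 1 to compound 4 (0.09 log units; within the scatter).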

Compound 4, concentration for 50% growth inhibition: 14800 nM
For compound 4 the middle estimate is 2.1-fold (0.33 log units) below the measured one; the measured number falls inside the stated range.
By their numbers in this assay, from the lowest: compounds 1, 4 and 2 (each within the scatter of the next); then compound 3.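

In this assay, the 3,4-dimethoxyphenyl to 4-methoxyphenyl change gives a 1.7-fold higher number from compound 1 to compound 4 (0.23 log units; within the scatter), so taking a methoxy away from this aromatic carbon, ortho to a methoxy group and meta to a large group, does not separate the two compounds. The earlier data showed only the addition of a methoxy, a 1.9-fold higher number from compound 1 to compound 2 (0.27 log units; within the scatter), and with both steps within the scatter, neither direction of change at this ring gives a readable difference among these three compounds. No measurement is available that could explain this result.

The compounds shown leave open whether a group other than methoxy on this aromatic carbon, such as a hydroxyl, an amine or a carboxylic acid, would move the number beyond the scatter. They also leave open what would happen if the remaining methoxy were replaced by hydrogen.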